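One Chlorine Added to a Weak Cytotoxic Compound

This account rests on a few compounds, and the source may have more. Where it says the series, first, only, none or still open, it means among the compounds named here.

Within the data shown here, compound 2 `Cc1nc(Nc2ccccc2)sc1C(=O)/C=C/c1ccccc1` is the only compound here with a plain number: in a functional assay on BGC-823 cells (Homo sapiens) for cytotoxicity, read by MTT assay (a higher number here means a weaker inhibitor, a lower number a stronger inhibitor), compound 2 gives 19500 nM. Compound 1 `Cc1ccccc1Nc1nc(C)c(C(=O)/C=C/c2ccccc2Cl)s1` reaches only a limit of the assay, giving > 25000 nM in this assay. Compound 3 `Cc1nc(Nc2ccccc2)sc1C(=O)/C=C/c1ccccc1Cl` has not yet been measured; it differs from compound 2 in one place, (chloro in place of hydrogen on an aromatic carbon). Among the measured compounds shown here, no measured pair shows this change on its own, so its size is not known; the step of a 1.1-fold higher number from compound 2 to compound 3 (0.05 log units; within the scatter) is expected to stay within the scatter or lean slightly toward weaker. Compound 3 is expected to give 22000 nM, between 9000 nM and 50000 nM, possibly only as a limit.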

Compound 3, half-maximal inhibitory concentration: 22800 nM
The estimate for compound 3 lay 1.0-fold (0.02 log units) below the measured number; measured number inside the range.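

Chloro in place of hydrogen at this position, ortho to a large group, now has a size of its own in this assay: a 1.2-fold higher number from compound 2 to compound 3 (0.07 log units; within the scatter), so this change leaves compound 3 indistinguishable from compound 2. Hydrogen in place of methyl on an aromatic carbon gives an at least 1.0-fold lower number from compound 1 to compound 3 (0.04 log units; that floor lies within the scatter), which can be read only as a floor because compound 1 stands at a limit of the assay: the limit of > 25000 nM in this assay, at which 1 of the 3 values shown sits.

The compounds shown leave open whether any other group at this position would change the number. Going by these compounds, an amine or a carboxylic acid in place of the chloro remains untested here.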